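Urea series on a shared core: aryl to benzyl on the urea nitrogen

The source may report more compounds than this note shows. Statements on the series, on what has been measured and on what is new or still open speak of the compounds shown alone.

Three ureas built on one core have been measured so far. Compound 1 `COc1ccc(OC)c(NC(=O)Nc2nn(-c3ccccc3)c(=O)c3ccccc23)c1` carries a 2,5-dimethoxyphenyl on the amide-type nitrogen; in an assay on CHO cells for displacement of a labelled ligand from adenosine receptor A1 (Homo sapiens), tested at 10 uM (a higher number here means more inhibition at the concentration tested (going by the name of the read-out), a lower number less inhibition), compound 1 gives 0%. Compound 2 `O=C(Nc1ccc(Cl)cc1)Nc1nn(-c2ccccc2)c(=O)c2ccccc12` carries a 4-chlorophenyl in that place, and in this assay compound 2 gives 10%. Compound 3 `COc1ccc(NC(=O)Nc2nn(-c3ccccc3)c(=O)c3ccccc23)cc1` carries a 4-methoxyphenyl, and in this assay compound 3 gives 4%. All three numbers lie within the usual scatter of one another: a number 4 percentage points higher from compound 1 to compound 3 (within the scatter), and a number 6 percentage points lower from compound 2 to compound 3 (within the scatter). Compound 3 therefore stands at neither end of anything that the numbers can distinguish.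

The next compound, compound 4 `O=C(NCc1ccccc1)Nc1nn(-c2ccccc2)c(=O)c2ccccc12`, differs from compound 3 in one place: benzyl in place of 4-methoxyphenyl on an amide-type nitrogen. For the measured compounds named here, no measured step exchanges an aryl for a benzyl on this nitrogen, so the two steps touching compound 3 are the only guidance; both change the substituent pattern on the aryl group and both stay within the scatter. Going by the values given here, since every variation at this position so far has left the number near zero, no step beyond the scatter is expected in this assay for compound 4: a number 1 percentage points higher from compound 3 to compound 4 (within the scatter). The estimate for compound 4 is 5%, with a range from -5% to 15%.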

Compound 4, a percentage reported as inhibition, at one concentration (the size of the read-out at that concentration, not a potency): 20%
Estimate against measurement, compound 4: 15 percentage points below; the whole stated range lies below it.
By their numbers in this assay, from the lowest: compounds 1, 3, 2 and 4 (each within the scatter of the next, the first and the last beyond it).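

In this assay this nitrogen now shows a single change that moves the number beyond the scatter, with benzyl as the group involved: the step is seen both in (a number 16 percentage points higher from compound 3 to compound 4 (beyond the scatter)) and in (a number 20 percentage points higher from compound 1 to compound 4 (beyond the scatter)). The separation is only partial, since compound 2 goes against it (a number 10 percentage points higher from compound 2 to compound 4 (within the scatter)), so benzyl stands apart from the methoxy-bearing aryl groups of compound 1 and compound 3 but not from the 4-chlorophenyl of compound 2, and compound 4 at 20% remains a read-out at one concentration, not a potency. Nothing at hand offers an explanation for these steps.

Open, as far as these compounds go, is whether a 4-methoxybenzyl or 4-chlorobenzyl on this nitrogen would keep the number of the plain benzyl or fall back towards the matching aryl ureas, which would show whether the aryl substituent or the benzyl link matters more. Also open, from the compounds shown here alone, is what a longer chain such as phenethyl, or a cyclohexyl with no aromatic ring, would give in this assay on the shared core.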